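The compounds below may be only part of what the source reports. "The series", "measured", "known", "first", "only" and "open" are said of these compounds alone.

Three compounds of this study share a core made of two aromatic rings joined to a central five-membered ring, and their growth inhibition was measured in a functional assay on SW-620 cells (Homo sapiens) for inhibition, read by MTT assay, with a stated time of 48 h; on this read-out higher numbers stand for weaker inhibition of growth and lower numbers for stronger inhibition of growth. Compound 1, with the structure `COc1ccc(-c2cc(-c3ccc([N+](=O)[O-])cc3)[nH]n2)cc1OC`, gives 26400 nM. Compound 2, with the structure `Nc1ccc(-c2cc(-c3ccccc3)n[nH]2)cc1`, gives 25400 nM. Compound 3, with the structure `COc1ccc(-c2cc(-c3ccccc3)n[nH]2)cc1`, gives 27200 nM. Within the data shown here, the only single-point step among them is a 1.1-fold higher number from compound 2 to compound 3 (0.03 log units; within the scatter). Compound 3 therefore sits among three numbers that all lie within the scatter of one another, so none of the three can be called stronger or weaker than the others.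

Compound 4, with the structure `COc1ccc(-c2cc(-c3ccc(C(F)(F)F)cc3)n[nH]2)cc1`, is not yet measured. It differs from compound 3 by trifluoromethyl in place of hydrogen on an aromatic carbon. Among the measured compounds shown here, no measured step places a trifluoromethyl group on any ring of this core, so the only step that bears on the change is the one from compound 2 to compound 3, which swapped one group on a ring for another and stayed within the scatter. Compound 4 is therefore expected to show no step beyond the scatter, namely a 1.1-fold lower number from compound 3 to compound 4 (0.04 log units; within the scatter). The estimate for compound 4 in this assay is 25000 nM, with a range from 8000 nM to 70000 nM.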

Compound 4, concentration for 50% growth inhibition: 11200 nM
Estimate against measurement, compound 4: 2.2-fold (0.35 log units) above, and the stated range covers the measured number.
By their numbers in this assay, from the lowest: compound 4; then compounds 2, 1 and 3 (each within the scatter of the next).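

Among the compounds measured before, the only single-place change stayed within the scatter, whereas in this assay trifluoromethyl in place of hydrogen gives a 2.4-fold lower number from compound 3 to compound 4 (0.39 log units; beyond the scatter) and so moves the number beyond it. This shows that the aromatic carbon para to a large group is a place where one substitution can strengthen growth inhibition, even though the step is modest. The added group has 4 heavy atoms, no ring, no hydrogen-bond donors or acceptors and no net charge, but nothing shown here explains why this change lowers the number.

On these data alone, it remains open whether the same place would respond in the same direction to a single fluorine atom, a nitrile, an amine, a carboxylic acid or a longer chain, so one substituent cannot yet be read as a trend. As far as these compounds go, it is also open whether trifluoromethyl would give a similar step on a core carrying amino rather than methoxy on the other aromatic ring, or whether the group would have the same effect at another place on its own ring.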